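The source may report more compounds than this note shows. Statements on the series, on what has been measured and on what is new or still open speak of the compounds shown alone.

Compound 1, `CC(C)(C)N(NC(=O)c1cccc(C#N)c1)C(=O)c1ccccc1Cl`, gives 955 nM.
Compound 2, `CCCc1ccc(C(=O)NN(C(=O)c2ccccc2Cl)C(C)(C)C)cc1`, gives 9.12 nM.

Of the compounds shown here, two have been measured in an assay on cells for agonist activity at ecdysone receptor (Bombyx mori), read by a luciferase reporter, with a stated time of 24 h; a lower number here means that less compound is needed, a higher number that more compound is needed for the effect. Compound 1 gives 955 nM, while compound 2 gives 9.12 nM. Compound 2 therefore stands at the lowest of the two numbers, and the gap to compound 1 is wide and well beyond the scatter, so the two compounds are clearly told apart by this assay.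

Compound 3, `COc1ccc(C(=O)NN(C(=O)c2ccccc2Cl)C(C)(C)C)cc1`, has not yet been measured. It differs from compound 2 in one place: methoxy in place of propyl on an aromatic carbon. Among the measured compounds shown here, no pair of measured compounds shows this change, so its size cannot be read from a step already seen. For the measured compounds named here, with only one other compound for comparison, and that one differing at a different part of the molecule, the step is expected to be modest, a small loss of potency, a rise in the number of moderate size but possibly within the scatter.

In this assay compound 3 is thus estimated at 40 nM, with a range from 8 nM to 200 nM. This estimate means a step from compound 2 to compound 3 of a 4.4-fold higher number from compound 2 to compound 3 (0.64 log units; beyond the scatter).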

Compound 3, half-maximal effective concentration: 51.3 nM
The estimate for compound 3 lay 1.3-fold (0.11 log units) below the measured number, and the stated range covers the measured number.
By their numbers in this assay, from the lowest: compound 2; then compound 3; then compound 1.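

In this assay, among the compounds shown here, methoxy in place of propyl on an aromatic carbon, para to a large group, gives a 5.6-fold higher number from compound 2 to compound 3 (0.75 log units; beyond the scatter) and so provides the first measured reading at this position: the two groups are not interchangeable there. The change of 4-methoxyphenyl in place of 3-cyanophenyl on a carbonyl carbon gives a 19-fold lower number from compound 1 to compound 3 (1.27 log units; beyond the scatter) and places compound 3 well on the lower side of compound 1, so a methoxy group at this position retains much of the low number seen with propyl, though not all of it. No measurement shown here speaks to the reason for either step.

Propyl and methoxy differ in both heavy-atom count and acceptor count, so these compounds leave open whether the number follows chain size or the oxygen atom, a question that ethyl, ethoxy or butyl at the same place could address. As far as these compounds go, the step from the nitrile compound changes both the group and its place, so it also remains open how 4-cyanophenyl or 3-methoxyphenyl on the carbonyl carbon would read.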